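Trimethoxyphenyl in place of methylphenyl on the ether carbon

The source may report more compounds than this note shows. Statements on the series, on what has been measured and on what is new or still open speak of the compounds shown alone.

Among the measured compounds shown here, compound 1 `Cc1ccccc1COc1ccc(-c2cc(CN3CCN(Cc4ccc(C(F)(F)F)cc4)CC3)no2)cc1` gives 1200 nM in a functional assay on Huh-7 cells (Homo sapiens) for antiproliferative activity, read by sulforhodamine B assay, with a stated time of 72 h (on this read-out lower numbers stand for stronger inhibition and higher numbers for weaker inhibition), the highest of the two numbers measured so far, while compound 2 `FC(F)(F)c1ccc(CN2CCN(Cc3cc(-c4ccc(OCc5cccc(Cl)c5)cc4)on3)CC2)cc1` gives 200 nM. For the measured compounds named here, the single measured step, a 6.0-fold lower number from compound 1 to compound 2 (0.78 log units; beyond the scatter), concerns the same saturated chain carbon bound to an oxygen on an aromatic ring and shows that exchanging the aryl group there moves the read-out beyond the scatter. Compound 3 `COc1cc(COc2ccc(-c3cc(CN4CCN(Cc5ccc(C(F)(F)F)cc5)CC4)no3)cc2)cc(OC)c1OC` differs from compound 1 by 3,4,5-trimethoxyphenyl in place of 2-methylphenyl on a saturated chain carbon bound to an oxygen on an aromatic ring. Going by the values given here, no measured step covers this group. Because a 6.0-fold lower number from compound 1 to compound 2 (0.78 log units; beyond the scatter) went lower, a modest lowering is expected, a 2.0-fold lower number from compound 1 to compound 3 (0.30 log units; within the scatter), with wide uncertainty. Compound 3 is estimated at 600 nM, between 150 nM and 2500 nM.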

Compound 3, half-maximal inhibitory concentration: 500 nM
Beside the measured number, compound 3's estimate is 1.2-fold (0.08 log units) above it; low and high end bracket the measured number.
By their numbers in this assay, from the lowest: compound 2; then compound 3; then compound 1.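

Both aryl exchanges on the saturated chain carbon bound to an oxygen on an aromatic ring now lower the number relative to 2-methylphenyl, and the oxygen-bearing 3,4,5-trimethoxyphenyl also gives a 2.4-fold lower number from compound 1 to compound 3 (0.38 log units; beyond the scatter). The position therefore accepts more than a halogen-bearing aryl group, yet 3-chlorophenyl remains ahead of it, with a 2.5-fold higher number from compound 2 to compound 3 (0.40 log units; beyond the scatter). No measurement available here bears on the reason for either difference.

Going by these compounds, it remains open whether the identity of the ring substituent or its place on the ring sets the number. A 3-methylphenyl group on this carbon would separate the two.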